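Swapping the benzyl arene: methyl out, chlorine in

The source may hold more compounds than are shown below. What is called first, only, known or untested is meant among the compounds shown, and "the series" means these compounds.

Compound 1 `Cc1cccc(CSc2cc(Cl)c(C)cc2S(=O)(=O)/N=C(\N)n2nccc2-c2ccccc2)c1` was tested in an ADME assay on microsomes from liver (Homo sapiens) for metabolic stability, read by LC-MS, using NADPH, tested at 5 uM (on this read-out lower numbers stand for a shorter-lived compound and higher numbers for a longer-lived compound), and gave 0.232 h. Its single companion, compound 2 `Cc1cccc(CSc2cc(Cl)c(C)cc2S(=O)(=O)/N=C(\N)n2nc(C)cc2-c2ccccc2)c1`, gave 0.214 h in this assay, so the two numbers sit within the scatter of each other; compound 1 is not separated from any other measured compound. Going by the values given here, the only measured step, a 1.1-fold lower number from compound 1 to compound 2 (0.04 log units; within the scatter), changes a hydrogen on an aromatic carbon of the shared core and so says nothing direct about the benzyl arene. Compound 3 `Cc1cc(S(=O)(=O)/N=C(\N)n2nccc2-c2ccccc2)c(SCc2ccccc2Cl)cc1Cl` differs from compound 1 in that arene: 2-chlorophenyl in place of 3-methylphenyl on a saturated chain carbon bound to a sulfur. Among the compounds with values here, no measured step addresses this exchange, so the expectation rests on the observation that compound 1 and compound 2 both sit in the same narrow band. Compound 3 is expected to show a step of a 1.1-fold higher number from compound 1 to compound 3 (0.03 log units; within the scatter), that is, no change beyond the scatter. Compound 3 is estimated at 0.25 h, within a range from 0.12 h to 0.5 h.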

Compound 3, half-life: 0.226 h
Estimate against measurement, compound 3: 1.1-fold (0.04 log units) above; measured number inside the range.
By their numbers in this assay, from the lowest: compounds 2, 3 and 1 (each within the scatter of the next).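

In this assay, putting 2-chlorophenyl in place of 3-methylphenyl on a saturated chain carbon bound to a sulfur gives a 1.0-fold lower number from compound 1 to compound 3 (0.01 log units; within the scatter). Going by these compounds alone, this is the first measured step at this position, as the earlier step lay elsewhere on the shared core, and it shows that this exchange of one aromatic ring for another leaves the half-life within the scatter. Nothing measured here offers an explanation for this result.

The compounds shown leave open whether a different kind of group at this position, such as a pyridine ring, a carboxylic acid or a longer chain, would move the half-life beyond the scatter. They also cannot tell how 3-chlorophenyl or 2-methylphenyl would behave, so the choice of substituent cannot be separated from its place on the ring.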